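The source may report more compounds than this note shows. Statements on the series, on what has been measured and on what is new or still open speak of the compounds shown alone.

Compound 1 `COC(=O)C1=C(C)N=C(C)/C(=C(/O)OC)C1c1cccc(N/C(=N/CCNC2CCN(c3ccccc3)CC2)NC#N)c1` is the reference point of this small series. In an assay on SK-N-MC cells for inhibition of Neuropeptide Y receptor type 1 (Homo sapiens) (a lower number here means a stronger inhibitor, a higher number a weaker inhibitor), compound 1 gives 10 nM, the highest of the three numbers recorded so far. Compound 2 `COC(=O)C1=C(C)N=C(C)/C(=C(/O)OC)C1c1cccc(N/C(=N/CCNC2CCN(c3ccccc3C)CC2)NC#N)c1` carries a methyl in place of hydrogen on an aromatic carbon and gives 4 nM in this assay; compound 3 `COC(=O)C1=C(C)N=C(C)/C(=C(/O)OC)C1c1cccc(N/C(=N/CCNC2CCN(c3ccccc3OC)CC2)NC#N)c1` carries a methoxy in place of hydrogen on an aromatic carbon and gives 4 nM. The steps read a 2.5-fold lower number from compound 1 to compound 2 (0.40 log units; beyond the scatter) and a 2.5-fold lower number from compound 1 to compound 3 (0.40 log units; beyond the scatter), while no change at the digits printed from compound 2 to compound 3 (within the scatter). Compound 4 `COC(=O)C1=C(C)N=C(C)/C(=C(/O)OC)C1c1cccc(N/C(=N/CCNC2CCN(c3cccc(Cl)c3)CC2)NC#N)c1` is the next member and has not yet been measured. It differs from compound 1 by chloro in place of hydrogen on an aromatic carbon, so that a phenyl becomes a 3-chlorophenyl. Among the compounds with values here, the two measured steps bear only loosely on it: each added a single small group to the same phenyl and each gave a modest gain, but no measured pair tests chloro at all, and the methyl and methoxy results give no indication of how far the gain depends on the group itself. One therefore expects a step of about a 1.7-fold lower number from compound 1 to compound 4 (0.22 log units; within the scatter), a modest gain or none beyond the scatter. For compound 4 one estimates 6 nM in this assay, with a range from 2.5 nM to 15 nM.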

Compound 4, half-maximal inhibitory concentration: 8 nM
The estimate for compound 4 lay 1.3-fold (0.12 log units) below the measured number; low and high end bracket the measured number.
By their numbers in this assay, from the lowest: compounds 2, 3, 4 and 1 (each within the scatter of the next, the first and the last beyond it).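

In this assay, the change from phenyl to 3-chlorophenyl gives a 1.3-fold lower number from compound 1 to compound 4 (0.10 log units; within the scatter), so adding a single group to this phenyl does not always produce a step beyond the scatter, as the methyl and methoxy steps did. The 3-chlorophenyl also cannot be separated from the 2-methylphenyl or the 2-methoxyphenyl, with a 2.0-fold higher number from compound 2 to compound 4 (0.30 log units; within the scatter) and a 2.0-fold higher number from compound 3 to compound 4 (0.30 log units; within the scatter), which places compound 4 within the scatter of all three earlier compounds, even though compounds 2 and 3 each lie beyond the scatter of compound 1. Nothing measured here bears on this result.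

Among the compounds shown, chloro appears only in the 3-chlorophenyl, while methyl and methoxy appear only in the 2-methylphenyl and the 2-methoxyphenyl, so the effect of the group cannot be separated from that of its place on the ring. As far as these compounds go, it also remains open whether a fluoro, an amine or a carboxylic acid on this phenyl would give a step beyond the scatter in this assay.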